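The source may hold more compounds than are shown below. What is called first, only, known or untested is meant among the compounds shown, and "the series" means these compounds.

Compounds measured in a functional assay on SK-MEL-2 cells (Homo sapiens) for inhibition, read by sulforhodamine B assay, with a stated time of 48 h, tested at 10 uM; on this read-out lower numbers stand for less inhibition and higher numbers for more inhibition at the one concentration tested (going by the name of the read-out):
compound 1 `c1cn2cc(-c3ccsc3)nc(-c3ccc4ncn(C5CCCCC5)c4c3)c2n1` gives 3.68%;
compound 2 `CC(=O)c1ccc(-c2cn3ccnc3c(-c3ccc4ncn(C5CCCCC5)c4c3)n2)cc1` gives 0.58%.

Compound 2 gives the lowest of the two numbers, with compound 1 nearest; the step of a number 3.1 percentage points lower from compound 1 to compound 2 (within the scatter) lies within the scatter. Compound 3 `Fc1ccccc1-c1cn2ccnc2c(-c2ccc3ncn(C4CCCCC4)c3c2)n1` is not yet measured. It differs from compound 2 by 2-fluorophenyl in place of 4-acetylphenyl on an aromatic carbon. Going by the values given here, the only step that bears on this is the exchange at the same aromatic carbon, a number 3.1 percentage points lower from compound 1 to compound 2 (within the scatter), which changed little. Compound 3 is therefore expected to stay low as well, with the step of a number 2.4 percentage points higher from compound 2 to compound 3 (within the scatter) within the scatter, and its value is estimated at 3% (range -8% to 15%).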

Compound 3, a percentage reported as inhibition, at one concentration (the size of the read-out at that concentration, not a potency): 10.5%
Estimate against measurement, compound 3: 7.5 percentage points below, within the range that was stated.
By their numbers in this assay, from the lowest: compounds 2, 1 and 3 (each within the scatter of the next).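

In this assay, 2-fluorophenyl in place of 4-acetylphenyl gives a number 9.9 percentage points higher from compound 2 to compound 3 (within the scatter), and 2-fluorophenyl in place of thiophen-3-yl gives a number 6.8 percentage points higher from compound 1 to compound 3 (within the scatter). Going by these compounds alone, this aromatic carbon has now carried three different aromatic rings, one with a fluorine and one with a carbonyl, and no step among them leaves the scatter, so all three compounds show little inhibition at the one concentration tested. On these data alone, whether an amine, a carboxylic acid or a longer chain at this carbon would raise the number beyond the scatter stays open. Nothing available explains why these numbers lie so close together.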